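Cytotoxicity notes on a shared-core amine series

This account rests on a few compounds, and the source may have more. Where it says the series, first, only, none or still open, it means among the compounds named here.

Measured compounds:
compound 1 `COC(=O)/C=C/C(=O)N[C@@H](C)Cn1ccc(-c2ccc(C#N)c(Cl)c2)n1`: in an ADME assay on PC-3 cells (Homo sapiens) for cytotoxicity, read by CCK-8 assay, with a stated time of 6 days (on this read-out higher numbers stand for weaker inhibition and lower numbers for stronger inhibition), compound 1 gives > 30000 nM, a limit of the assay.
compound 2 `C[C@@H](Cn1ccc(-c2ccc(C#N)c(Cl)c2)n1)NC(=O)C1CC(=O)C1`: in this assay compound 2 gives > 30000 nM, again a limit.
compound 3 `C[C@@H](Cn1ccc(-c2ccc(C#N)c(Cl)c2)n1)Nc1ccncc1`: in this assay compound 3 gives "not determined" (no result reported).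

Compound 3 thus has no number of its own; the two values shown for the series both sit at the limit of > 30000 nM in this assay, at which 2 of the 3 values shown sit. Within the data shown here, the one step between measured compounds, a step that the two limits leave unreadable from compound 1 to compound 2, is unreadable, since both ends are limits.

Compound 4 `C[C@@H](Cn1ccc(-c2ccc(C#N)c(Cl)c2)n1)Nc1ncccn1` differs from compound 3 by pyrimidin-2-yl in place of pyridin-4-yl on an amine nitrogen. Among the measured compounds shown here, no measured step bears on this change, and compound 3 itself carries no number, so no direction can be read for the step to compound 4. For the measured compounds named here, the only guide is that every value shown in this assay is a limit. Compound 4 is therefore expected to give 30000 nM, in a range of 10000 nM to 100000 nM, most likely reported as a limit again.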

Compound 4, half-maximal inhibitory concentration: > 30000 nM
Compound 4 was reported as a limit; the forecaster's own chance of this, stated with the estimate: 80%; the middle value sits exactly at the limit.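

Compound 4 gives > 30000 nM, a limit, so no new step can be read: its pairings with compound 1 and compound 2 have limits at both ends. The compounds shown leave open whether any change on the amine nitrogen moves the value in this assay, with the readings resting on one limit: the limit of > 30000 nM in this assay, at which 3 of the 4 values shown sit.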